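Swapping piperidin-1-yl for benzylamino in compound 4

The compounds below may be only part of what the source reports. "The series", "measured", "known", "first", "only" and "open" are said of these compounds alone.

Measured in a functional assay on MCF7 cells (Homo sapiens) for inhibition, read by sulforhodamine B assay; a lower number here means a stronger inhibitor, a higher number a weaker inhibitor
Compound 1 `CCc1ccc(NC2=CC(=O)c3c(nc4n3[C@H]3OC[C@@H](O)[C@H]3OC4)C2=O)cc1` gives 8990 nM
Compound 2 `Cc1ccc(NC2=CC(=O)c3c(nc4n3[C@H]3OC[C@@H](O)[C@H]3OC4)C2=O)cc1C` gives 4950 nM
Compound 3 `O=C1C(N2CCCCC2)=CC(=O)c2c1nc1n2[C@H]2OC[C@@H](O)[C@H]2OC1` gives > 8000 nM (a limit, not a number)

Compound 3 stands at the limit of > 8000 nM in this assay, at which 1 of the 3 values shown sits, and so has no exact value. Compound 4 `O=C1C(NCc2ccccc2)=CC(=O)c2c1nc1n2[C@H]2OC[C@@H](O)[C@H]2OC1` carries benzylamino in place of piperidin-1-yl on a double-bonded ring carbon and shares the core of compound 3.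

Benzylamino itself has not been measured, so the nearest guides are the steps that exchange piperidin-1-yl with an amino group bearing a ring. One, an at least 1.6-fold higher number from compound 2 to compound 3 (0.20 log units; that floor lies within the scatter), has a floor that lies within the scatter. The other, a step that the limit leaves unreadable from compound 1 to compound 3, cannot be read. The two aryl amines also sit within the scatter of each other, shown by a 1.8-fold lower number from compound 1 to compound 2 (0.26 log units; within the scatter), so no large shift is expected in this assay and any movement would most likely be towards a slightly lower number. The expected change is an at least 1.2-fold lower number from compound 3 to compound 4 (0.09 log units; that floor lies within the scatter) and no step beyond the scatter is anticipated. Compound 4 is estimated at 6500 nM, with an expected range from 2800 nM to 15000 nM.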

Compound 4, half-maximal inhibitory concentration: > 8000 nM
Compound 4: no number, only a limit (the forecaster's own chance of this, stated with the estimate: 30%); middle value at least 1.2-fold (0.09 log units) away from the limit.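

In this assay, compound 4 gives a limit and not a number, as compound 3 does: the limit of > 8000 nM in this assay, at which 2 of the 4 values shown sit. On this double-bonded ring carbon, then, benzylamino, with its aromatic ring and hydrogen-bond donor, gives no exact value any more than piperidin-1-yl does, and the steps from compound 1 and from compound 3 to compound 4 cannot be read. The one readable step is an at least 1.6-fold higher number from compound 2 to compound 4 (0.20 log units; that floor lies within the scatter), so placing benzyl instead of 3,4-dimethylphenyl on the amine nitrogen is not shown to weaken inhibition beyond ordinary scatter.

The compounds shown leave open how far above the limit compound 3 and compound 4 truly lie. They also leave open whether a small methylamino group, a longer phenethylamino chain or a morpholin-4-yl ring at this carbon would give a number clearly apart from these.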